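Fluoro in place of methoxy, with no acetyl

This account rests on a few compounds, and the source may have more. Where it says the series, first, only, none or still open, it means among the compounds named here.

In an ADME assay on MT4 cells (Homo sapiens) for cytotoxicity, read by MTT assay, with a stated time of 4 days (a lower number here means that less compound is tolerated, a higher number that more compound is tolerated), the measured compounds are:
Compound 1 `COc1cccc(-c2cc(=O)c3cc(NC(C)=O)ccc3o2)c1` gives > 404000 nM as a limit
Compound 2 `CC(=O)Nc1ccc2oc(-c3cccc(F)c3)cc(=O)c2c1` gives 240000 nM as its number
Compound 3 `COc1cccc(-c2cc(=O)c3cc(N)ccc3o2)c1` gives 247000 nM as its number

The values of compound 3 and compound 2 lie within the usual scatter of each other, so neither can be ranked over the other. Compound 1 has only a limit.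

Compound 4 `Nc1ccc2oc(-c3cccc(F)c3)cc(=O)c2c1` differs from compound 3 by fluoro in place of methoxy on an aromatic carbon and in no other way. The same swap gives an at least 1.6-fold lower number from compound 1 to compound 2 (0.22 log units; that floor lies within the scatter) and is the closest guide. Hydrogen in place of acetyl on a nitrogen gives an at least 1.6-fold lower number from compound 1 to compound 3 (0.21 log units; that floor lies within the scatter) and bears on the question less directly. Both are only floors because of the limit of > 404000 nM in this assay, at which 1 of the 3 values shown sits, and so a larger true step cannot be ruled out. Starting from compound 3 at 247000 nM no step beyond the scatter is expected in this assay on this evidence. The expected change is a 1.1-fold lower number from compound 3 to compound 4 (0.03 log units; within the scatter) as an estimate. Expected for compound 4 is 230000 nM with 110000 nM to 430000 nM as the estimated range.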

Compound 4, half-maximal cytotoxic concentration: 269000 nM
For compound 4 the middle estimate is 1.2-fold (0.07 log units) below the measured one; measured number inside the range.
By their numbers in this assay, from the lowest: compounds 2, 3 and 4 (each within the scatter of the next). At a limit, above all of these: compound 1.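

In this assay, fluoro in place of methoxy on the core without the acetyl gives a 1.1-fold higher number from compound 3 to compound 4 (0.04 log units; within the scatter), and hydrogen in place of acetyl on the nitrogen of the fluoro compound gives a 1.1-fold higher number from compound 2 to compound 4 (0.05 log units; within the scatter). Among the compounds shown here, these are the first steps for either change with a plain number at both ends, and both lie within the scatter, so on these compounds neither change shifts the tolerated concentration measurably. Whether the fluoro swap acts the same way on the acetyl-bearing core cannot be settled: the same change on two cores in this assay, an at least 1.6-fold lower number (0.22 log units; that floor lies within the scatter) from compound 1 to compound 2 and a 1.1-fold higher number (0.04 log units; within the scatter) from compound 3 to compound 4; the limit leaves it open whether they differ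

Open, on these data alone, is whether a different group on this aromatic carbon, such as a nitrile or a trifluoromethyl, or a longer chain on the nitrogen in place of the acetyl, would move the number beyond the scatter. How far compound 1 truly lies from the others also stays open: the limit of > 404000 nM in this assay, at which 1 of the 4 values shown sits.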